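Replacing nitro with ethynyl: compound 2 to compound 3

A few compounds are considered here, and "the series" means these few. Any claim that something is new, unique, unknown or untested is made for them only; others in the source may bear on it.

Measured so far:
compound 1 `CCCc1cc(C(=O)N[C@H](C)CCCc2cccnc2)ccc1-c1ccc(OC)c(OC)c1`: 50 nM
compound 2 `COc1ccc(-c2ccc(C(=O)N[C@H](C)CCCc3cccnc3)cc2[N+](=O)[O-])cc1OC`: 200 nM

In an assay (Canis lupus familiaris) for binding affinity to platelet-activating factor receptor (Homo sapiens), read by radioligand binding (a higher number here means a weaker inhibitor, a lower number a stronger inhibitor), compound 2 gives the higher of the two numbers and compound 1 the lower one. For the measured compounds named here, the only step available is a 4.0-fold higher number from compound 1 to compound 2 (0.60 log units; beyond the scatter). Compound 3 `C#Cc1cc(C(=O)N[C@H](C)CCCc2cccnc2)ccc1-c1ccc(OC)c(OC)c1` carries ethynyl in place of nitro on an aromatic carbon. Going by the values given here, no measured step covers this exact exchange; the single bearing is that nitro gave a higher number than propyl at the same place. Since ethynyl, like propyl, is carbon-only, a number between those two is expected, which means a 2.5-fold lower number from compound 2 to compound 3 (0.40 log units; beyond the scatter). Compound 3 is therefore estimated at 80 nM, within a range of 30 nM to 250 nM.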

Compound 3, half-maximal inhibitory concentration: 5 nM
Compound 3: the middle estimate sits 16-fold (1.20 log units) above what was measured; the measured number lies below the stated range.
By their numbers in this assay, from the lowest: compound 3; then compound 1; then compound 2.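

In this assay ethynyl gives the lowest number yet at this aromatic carbon, with a 10-fold lower number from compound 1 to compound 3 (1.00 log units; beyond the scatter) and a 40-fold lower number from compound 2 to compound 3 (1.60 log units; beyond the scatter). Being carbon-only therefore does not settle the outcome here, since propyl and ethynyl, both carbon-only, stand clearly apart. No measurement available here explains the gain.

Still open, going by these compounds, is whether ethyl, vinyl or nitrile at this position would give a number nearer compound 3 or compound 1. Also open, on these data alone, is whether a longer alkyne, such as propynyl, would keep the low number of compound 3.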